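The source may report more compounds than this note shows. Statements on the series, on what has been measured and on what is new or still open speak of the compounds shown alone.

Of the compounds shown here, three built on one shared core have been measured in a functional assay for inhibition, tested at 100 ug/mL; a lower number here means a weaker effect, a higher number a stronger effect of the compound at the concentration tested. Compound 1 `Cc1cc(O)c(C(C)C)cc1-c1cc(-c2ccccc2Cl)c(C#N)c(=O)[nH]1` gives 34%. Compound 2 `COc1ccc(-c2cc(-c3cc(C(C)C)c(O)cc3C)[nH]c(=O)c2C#N)cc1OC` gives 61%. Compound 3 `Cc1cc(O)c(C(C)C)cc1-c1cc(-c2ccc(N(C)C)cc2)c(C#N)c(=O)[nH]1` gives 68%, the highest of the three numbers, though its gap to compound 2 lies within the scatter and only its gap to compound 1 lies beyond it. The measured steps are a number 27 percentage points higher from compound 1 to compound 2 (beyond the scatter), a number 34 percentage points higher from compound 1 to compound 3 (beyond the scatter) and a number 7 percentage points higher from compound 2 to compound 3 (within the scatter).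

Compound 4 `COc1ccc(-c2cc(-c3cc(C(C)C)c(O)cc3C)[nH]c(=O)c2C#N)cc1` has not yet been measured. It differs from compound 3 in one place: methoxy in place of dimethylamino on an aromatic carbon. Among the compounds with values here, no measured step makes exactly this change. Within the data shown here, the one that comes closest exchanges one such group for another on an aromatic carbon, a number 7 percentage points higher from compound 2 to compound 3 (within the scatter), and that stayed within the scatter; the larger steps, a number 34 percentage points higher from compound 1 to compound 3 (beyond the scatter) and a number 27 percentage points higher from compound 1 to compound 2 (beyond the scatter), each start from a different group. A small drop, or none beyond the scatter, is therefore expected for compound 4, a number 10 percentage points lower from compound 3 to compound 4 (within the scatter). The estimated value of compound 4 in this assay is 58%, ranging from 40% to 74%.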

Compound 4, a percentage reported as inhibition, at one concentration (the size of the read-out at that concentration, not a potency): 54%
Compound 4: the middle estimate sits 4 percentage points above what was measured; low and high end bracket the measured number.
By their numbers in this assay, from the lowest: compound 1; then compounds 4, 2 and 3 (each within the scatter of the next, the first and the last beyond it).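

In this assay, within the data shown here, methoxy in place of dimethylamino on an aromatic carbon, para to a large group, gives a step beyond the scatter (a number 14 percentage points lower from compound 3 to compound 4 (beyond the scatter)), so the single group at this position can shift the read-out on its own. Hydrogen in place of one methoxy of compound 2 gives a step that stays within the scatter (a number 7 percentage points lower from compound 2 to compound 4 (within the scatter)), so the second methoxy makes no clear difference here. The 4-methoxyphenyl group also stays clear of 2-chlorophenyl (a number 20 percentage points higher from compound 1 to compound 4 (beyond the scatter)), which places compound 2, compound 3 and compound 4 all beyond the scatter above compound 1.

Nothing available explains why these groups differ. As far as these compounds go, what a primary amine, a hydroxyl or an ethoxy group would give on this same carbon remains open.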